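Removing One Chloro From a Dichloropurine Cytotoxic

The compounds below may be only part of what the source reports. "The series", "measured", "known", "first", "only" and "open" are said of these compounds alone.

Compound 1 `ClCc1cccc(Cn2cnc3c(Cl)nc(Cl)nc32)c1` was tested in a functional assay on SNB-75 cells (Homo sapiens) for cytotoxicity, read by sulforhodamine B assay, with a stated time of 48 h (on this read-out lower numbers stand for higher toxicity in this test and higher numbers for lower toxicity in this test), where compound 1 gives 7410 nM. Among the compounds with values here, that is the only number in this set: compound 2 `ClCc1ccccc1Cn1cnc2c(Cl)nc(Cl)nc21` in this assay stands as "not determined" (no result reported), and compound 3 `ClCc1ccc(Cn2cnc3ncnc(Cl)c32)cc1` in this assay stands as "not determined" (no result reported), so compound 1 cannot be ranked against anything; it stands alone as the single point of reference.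

Compound 4 `ClCc1cccc(Cn2cnc3c(Cl)ncnc32)c1` differs from compound 1 in exactly one place: hydrogen in place of chloro on an aromatic carbon. Everything else, the chloromethyl-bearing benzyl group and the fused two-ring core, stays as it is.

Within the data shown here, no step between two measured compounds is available here, so the size of this change has to be estimated rather than read off a comparison. Among the measured compounds shown here, only a single chlorine leaves the core, and nothing in the data argues for a strong effect in either direction, so the step is expected to be modest, most likely a slight loss of toxicity that may not exceed the usual scatter of repeated measurements. For compound 4 the expected result in this assay is 11000 nM, with a range from 4000 nM to 30000 nM. Expressed as a step, this expectation amounts to a 1.5-fold higher number from compound 1 to compound 4 (0.17 log units; within the scatter).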

Compound 4, concentration lethal to 50% of the cells: 10000 nM
For compound 4 the middle estimate is 1.1-fold (0.04 log units) above the measured one, and the stated range covers the measured number.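

In this assay, putting hydrogen in place of chloro on the aromatic carbon between two ring nitrogen atoms gives a 1.3-fold higher number from compound 1 to compound 4 (0.13 log units; within the scatter). Within the data shown here, this is the first comparison in the set, and it shows that compound 1 and compound 4 cannot be told apart in this test, so for this one pair the chloro at this position makes no difference that can be read beyond the normal variation between repeated measurements. Nothing available explains this result, and no separate measurement shows what the chloro does at this position.

On these data alone, only chloro and hydrogen are seen on this carbon, so it remains open whether a larger or different group, such as an amine, a methoxy group or a longer carbon chain, would move the number beyond the scatter. The second chloro on the core and the chloromethyl group are the same in compound 1 and compound 4, so this pair says nothing about how much either one contributes to the toxicity seen in this test.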